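Swapping the group on the carbonyl carbon: working notes

A few compounds are considered here, and "the series" means these few. Any claim that something is new, unique, unknown or untested is made for them only; others in the source may bear on it.

Measured in a functional assay on A549 cells (Homo sapiens) for antiproliferative activity, read by MTT assay, with a stated time of 48 h; on this read-out higher numbers stand for weaker inhibition and lower numbers for stronger inhibition:
- Compound 1 `COc1ccc(/C=C/c2cc(OC)cc(OC)c2/C=C/C(=O)c2ccccc2C)cc1`: 5.9 ug/mL
- Compound 2 `COc1ccc(/C=C/c2cc(OC)cc(OC)c2/C=C/C(=O)c2ccc(C)c(C)c2)cc1`: 0.1 ug/mL

Compound 2 holds the lower of the two numbers, and so the stronger inhibition of the pair. Compound 3 `CCN(CC)c1ccc(C(=O)/C=C/c2c(/C=C/c3ccc(OC)cc3)cc(OC)cc2OC)cc1` alters the same place: 4-(diethylamino)phenyl in place of 3,4-dimethylphenyl on a carbonyl carbon. For the measured compounds named here, one measured step bears on this, a 59-fold lower number from compound 1 to compound 2 (1.77 log units; beyond the scatter). It was large and also exchanged the group on the carbonyl carbon, so a sizeable shift here would not be surprising. That step says nothing directly about a 4-(diethylamino)phenyl group. Going by the values given here, with compound 2 at 0.1 ug/mL, the low end of only two numbers, a moderate move toward a higher number in this assay is expected, with wide uncertainty. The expected step is an 8.0-fold higher number from compound 2 to compound 3 (0.90 log units; beyond the scatter). For compound 3 the estimated value is 0.8 ug/mL, with an expected range of 0.1 ug/mL to 6 ug/mL.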

Compound 3, half-maximal inhibitory concentration: 5.4 ug/mL
For compound 3 the middle estimate is 6.8-fold (0.83 log units) below the measured one, within the range that was stated.
By their numbers in this assay, from the lowest: compound 2; then compounds 3 and 1 (each within the scatter of the next).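

In this assay the 4-(diethylamino)phenyl group on the carbonyl carbon does not keep what 3,4-dimethylphenyl held: there is a 54-fold higher number from compound 2 to compound 3 (1.73 log units; beyond the scatter) and this step is about as large as the earlier one in the opposite direction. Set against the 2-methylphenyl group, the same change gives a 1.1-fold lower number from compound 1 to compound 3 (0.04 log units; within the scatter) and this lies within the scatter, so the two groups cannot be told apart here and only the 3,4-dimethylphenyl group of compound 2 stands apart among the three. Nothing available explains why this position responds so sharply to the group it carries.

Still open, on these data alone, is how an unsubstituted phenyl group, a smaller amine or a carboxylic acid would behave at this place. Whether the low number of compound 2 needs both methyl groups also remains unresolved.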